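A few compounds are considered here, and "the series" means these few. Any claim that something is new, unique, unknown or untested is made for them only; others in the source may bear on it.

Measured compounds:
compound 1 `CN(C)Cc1cc(OC/C=C\C/N=c2\c(O)c(O)c2=N)cs1`: 0.22 ug/mL
compound 2 `CN(C)CC/N=c1\c(O)c(O)\c1=N/C/C=C\COc1csc(CN2CCCCC2)c1`: 0.35 ug/mL
compound 3 `C=CCNc1c(NC/C=C\COc2csc(CN3CCCCC3)c2)c(=O)c1=O`: 0.51 ug/mL

All three numbers come from a functional assay for antagonist activity at histamine H2 receptor (Cavia porcellus); on this read-out lower numbers stand for stronger inhibition and higher numbers for weaker inhibition. Compound 2 stands second highest of the three numbers. Its nearest neighbour is compound 3, whose number is somewhat higher but within the scatter; its furthest is compound 1, whose number is somewhat lower, again within the scatter. No two of the measured compounds differ in only one place, so no single step can be read from them, and the three numbers do not separate from one another on this read-out.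

Compound 4 `C/N=c1\c(O)c(O)\c1=N/C/C=C\COc1csc(CN2CCCCC2)c1` is not yet measured. It differs from compound 2 by hydrogen in place of (dimethylamino)methyl on a saturated chain carbon bound to a double-bonded nitrogen; the same difference, cut one bond further out, reads 2-(dimethylamino)ethyl to methyl. Among the compounds with values here, the measured set contains no step of this kind, so the expectation rests on the narrow spread of the three numbers, which all lie within the scatter of each other although they differ at this position and elsewhere. The step from compound 2 to compound 4 is therefore expected to be small, a 1.3-fold higher number from compound 2 to compound 4 (0.11 log units; within the scatter), leaning toward a slightly higher number but not clearly beyond the scatter. Compound 4 is expected to give 0.45 ug/mL in this assay, with a range from 0.15 ug/mL to 1.4 ug/mL.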

Compound 4, half-maximal inhibitory concentration: 0.69 ug/mL
For compound 4 the middle estimate is 1.5-fold (0.19 log units) below the measured one, and the stated range covers the measured number.
By their numbers in this assay, from the lowest: compounds 1, 2, 3 and 4 (each within the scatter of the next, the first and the last beyond it).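

In this assay the series now has its first step that changes one place only: a 2.0-fold higher number from compound 2 to compound 4 (0.29 log units; within the scatter) stays within the scatter. At this position, a saturated chain carbon bound to a double-bonded nitrogen, hydrogen can therefore stand in place of (dimethylamino)methyl, which reads as 2-(dimethylamino)ethyl to methyl when cut one bond further out, with no change that separates from the scatter on this read-out. The loss of these four heavy atoms, among them the nitrogen of the dimethylamino group, thus leaves the number within reach of the parent compound, although nothing available bears on why this is so.

On these data alone, this is a single step, taken on the piperidinylmethyl-bearing parent of compound 2, so it remains open whether the same tolerance holds with the other groups seen elsewhere. Also open, as far as these compounds go, is how this position responds to groups of a different kind, such as a carboxylic acid, a hydroxyl or a longer chain ending in an amine, any of which could show whether the read-out moves beyond the scatter here.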